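The source may hold more compounds than are shown below. What is called first, only, known or untested is meant among the compounds shown, and "the series" means these compounds.

Measured compounds in this assay:
compound 1 `COc1ccc(NC(=O)[C@@H]2CC=C(CCC=C(C)C)C[C@H]2c2ccccc2)cc1` — in an assay on isolated protein for inhibition of Apoptosis regulator Bcl-2 (Homo sapiens), read by fluorescence polarization, with stated times of 5 min and 10 min (a higher number here means a weaker inhibitor, a lower number a stronger inhibitor), compound 1 gives > 23000 nM, which is a limit of the assay and not a number.
compound 2 `CC(C)=CCCC1=CC[C@H](C(=O)N(C)O)[C@@H](c2ccccc2)C1` — in this assay compound 2 gives 2100 nM.
compound 3 `COC(=O)CCNC(=O)[C@@H]1CC=C(CCC=C(C)C)C[C@H]1c1ccccc1` — in this assay compound 3 gives > 23000 nM, a limit and not a number.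

Compound 3 thus stands at the limit of the assay, the same place as compound 1 (the limit of > 23000 nM in this assay, at which 2 of the 3 values shown sit); compound 2 is the only one of the three with an actual number. Among the compounds with values here, the one step that touches compound 3, a step that the two limits leave unreadable from compound 1 to compound 3, cannot be read, as both ends are limits.

Compound 4 `CC(C)=CCCC1=CC[C@@H](C(=O)Nc2ccc(C(=O)O)cc2)[C@H](c2ccccc2)C1` is reached from compound 3 by 4-carboxyphenyl in place of 2-(methoxycarbonyl)ethyl on an amide-type nitrogen. No measured step covers a change of this kind: the only step within the shown set has no readable size, and compound 2 carries a different group on the amide nitrogen, with no step set down toward compound 1 or compound 3. The expectation for compound 4 therefore rests only on compound 3 sitting at the limit, with no direction indicated; a step of an at least 1.9-fold lower number from compound 3 to compound 4 (0.28 log units; that floor lies within the scatter) is estimated, with wide uncertainty. Compound 4 is estimated at 12000 nM, within a range of 3000 nM to 40000 nM, and a limit-only result remains quite possible.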

Compound 4, inhibition constant: 2200 nM
Beside the measured number, compound 4's estimate is 5.5-fold (0.74 log units) above it, outside the stated range (below it).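

In this assay, the amide-type nitrogen proves to be a place where the substituent alone can bring a compound off the limit: the change to 4-carboxyphenyl gives an at least 10-fold lower number from compound 3 to compound 4 (1.01 log units; beyond the scatter). The sharper comparison is with the 4-methoxyphenyl amide, where carboxy in place of methoxy on an aromatic carbon gives an at least 10-fold lower number from compound 1 to compound 4 (1.01 log units; beyond the scatter), so an aromatic ring on this nitrogen does not by itself yield a readable number, and the group on that ring makes the difference within this pair. Both steps fix only a minimum size, and the true gaps stay unknown, as each starts from a compound that is held at a limit and not at a number: the limit of > 23000 nM in this assay, at which 2 of the 4 values shown sit.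

Still open, going by these compounds, is whether the aromatic ring is needed at all, which 2-carboxyethyl on the same nitrogen, the free acid of the ester chain in compound 3, would test. Equally open, on these data alone, is whether the carboxy group itself is required on the ring, or whether a primary amide, a sulfonic acid or an aminomethyl group in its place would also give a readable value.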